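Notes on a thiazolyl-pyrazole series: growth inhibition

The source may hold more compounds than are shown below. What is called first, only, known or untested is meant among the compounds shown, and "the series" means these compounds.

Values in an ADME assay on A549 cells (Homo sapiens) for inhibition, read by MTT assay; on this read-out higher numbers stand for weaker inhibition of growth and lower numbers for stronger inhibition of growth:
Compound 1 `Cc1nc(C)c(-c2nn(-c3ccc(F)cc3)cc2/C=C/C(=O)c2cc(Br)ccc2O)s1`: > 250 ug/mL, a limit of the assay.
Compound 2 `Cc1nc(C)c(-c2nn(-c3ccc(F)cc3)cc2/C=C/C(=O)c2cc(Cl)cc(Cl)c2O)s1`: > 250 ug/mL, a limit of the assay.
Compound 3 `Cc1nc(C)c(-c2nn(-c3ccc(F)cc3)cc2C2CC(c3cc(Br)ccc3O)=NN2)s1`: 81.4 ug/mL.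

Among the compounds with values here, compound 3 holds the only number in this assay; the two other entries are limits. The step that the two limits leave unreadable from compound 1 to compound 2 is unreadable because the limit of > 250 ug/mL in this assay, at which 2 of the 3 values shown sit, covers both ends, and it sits on a carbonyl carbon, not on the ring of compound 3.

Compound 4 `Cc1nc(C)c(-c2nn(-c3ccc(F)cc3)cc2C2CC(c3c(O)cc(C)c(Cl)c3C)=NN2)s1` differs from compound 3 by 3-chloro-6-hydroxy-2,4-dimethylphenyl in place of 5-bromo-2-hydroxyphenyl on a carbon with a double bond to nitrogen. Within the data shown here, no measured step bears on this change, so nothing beyond the scatter is expected: the estimated step is a 1.0-fold lower number from compound 3 to compound 4 (0.01 log units; within the scatter). Compound 4 is expected at 80 ug/mL, within 30 ug/mL to 200 ug/mL.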

Compound 4, concentration for 50% growth inhibition: 43.4 ug/mL
Estimate against measurement, compound 4: 1.8-fold (0.27 log units) above; low and high end bracket the measured number.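

In this assay, 3-chloro-6-hydroxy-2,4-dimethylphenyl in place of 5-bromo-2-hydroxyphenyl gives a 1.9-fold lower number from compound 3 to compound 4 (0.27 log units; within the scatter). Within the data shown here, this is the first readable step, and it lies on the carbon with a double bond to nitrogen, not on a carbonyl carbon. The entering group has 10 heavy atoms against 8 for the one leaving, and the number does not move beyond the scatter.

The chlorine and the two methyl groups enter together, so their separate shares cannot be read. As far as these compounds go, whether an amine or a carboxylic acid on this phenyl ring would move the number beyond the scatter remains open.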